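The compounds below may be only part of what the source reports. "The series", "measured", "known", "first", "only" and "open" are said of these compounds alone.

Measured in a functional assay on SMMC-7721 cells (Homo sapiens) for cytotoxicity, read by MTT assay, with a stated time of 24 h; on this read-out higher numbers stand for weaker inhibition and lower numbers for stronger inhibition:
- compound 1 `O=C1/C(=C/c2cccnc2)CN(S(=O)(=O)c2ccccc2)C/C1=C\c1ccccc1C(F)(F)F`: 10900 nM
- compound 2 `O=C1/C(=C/c2cccnc2)CN(S(=O)(=O)c2ccc(Cl)cc2)C/C1=C\c1ccccc1C(F)(F)F`: 4880 nM

Of the two, compound 2 has the lower number in this assay, at 4880 nM. Compound 3 `CC(=O)Nc1ccc(S(=O)(=O)N2C/C(=C\c3cccnc3)C(=O)/C(=C/c3ccccc3C(F)(F)F)C2)cc1` differs from it as follows: acetamido in place of chloro on an aromatic carbon. This is acetamido in place of chloro on an aromatic carbon. Within the data shown here, only one measured step bears on this change, the modest 2.2-fold lower number from compound 1 to compound 2 (0.35 log units; beyond the scatter), where chloro came in place of hydrogen. Among the measured compounds shown here, no measured compound carries acetamido, so the expectation is loose. With chloro gone, a small move toward weaker inhibition is expected, namely a 1.6-fold higher number from compound 2 to compound 3 (0.21 log units; within the scatter). Compound 3 is estimated at 8000 nM, with an expected range of 3000 nM to 20000 nM.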

Compound 3, half-maximal inhibitory concentration: 9830 nM
Compound 3: middle estimate off by 1.2-fold (0.09 log units), on the low side, within the range that was stated.
By their numbers in this assay, from the lowest: compounds 2, 3 and 1 (each within the scatter of the next, the first and the last beyond it).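

In this assay, acetamido in place of chloro at this position gives a 2.0-fold higher number from compound 2 to compound 3 (0.30 log units; within the scatter), while acetamido in place of hydrogen gives a 1.1-fold lower number from compound 1 to compound 3 (0.04 log units; within the scatter), so compound 3 lies within the scatter of both neighbours. Chloro therefore remains the only one of these substituents whose step from hydrogen is beyond the scatter, and acetamido cannot be told apart from either. Nothing given here accounts for these numbers. As far as these compounds go, whether an amine or a carboxylic acid at this position would stand clear of hydrogen remains open.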